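Replacing Methyl with Trimethoxyphenyl: Expected Cytotoxicity

A few compounds are considered here, and "the series" means these few. Any claim that something is new, unique, unknown or untested is made for them only; others in the source may bear on it.

Measured in a functional assay on HepG2 cells (Homo sapiens) for cytotoxicity, read by MTT assay, with a stated time of 48 h; on this read-out lower numbers stand for stronger inhibition and higher numbers for weaker inhibition:
compound 1 `Cc1nnc(SCc2ccccc2)n1N1C(=O)c2ccccc2C1=O` gives > 200000 nM, a limit of the assay.
compound 2 `Cc1nnc(SCc2ccccc2Cl)n1N1C(=O)c2ccccc2C1=O` gives > 200000 nM, a limit of the assay.

Both results are limits, not numbers, so the step that the two limits leave unreadable from compound 1 to compound 2 cannot be read. Compound 2 therefore stands only at a limit, as the limit of > 200000 nM in this assay, at which 2 of the 2 values shown sit, shows. Compound 3 `COc1cc(-c2nnc(SCc3ccccc3Cl)n2N2C(=O)c3ccccc3C2=O)cc(OC)c1OC` differs from compound 2 by 3,4,5-trimethoxyphenyl in place of methyl on an aromatic carbon. Among the measured compounds shown here, no measured step speaks to this change, and the one measured step was unreadable, so no direction beyond the scatter can be foreseen in this assay. Compound 3 is expected to give 150000 nM (range 30000 nM to 400000 nM), quite possibly again as a limit. This estimate implies an expected step of an at least 1.3-fold lower number from compound 2 to compound 3 (0.12 log units; that floor lies within the scatter).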

Compound 3, half-maximal inhibitory concentration: > 200000 nM
Compound 3: a limit, no number; the forecaster's own chance of this, stated with the estimate: 55%; at least 1.3-fold (0.12 log units) between middle value and limit.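

In this assay compound 3, like compound 2, gives only a limit, so no step between compound 2 and compound 3 can be read: the limit of > 200000 nM in this assay, at which 3 of the 3 values shown sit.

As far as these compounds go, whether the chloro or the 3,4,5-trimethoxyphenyl change alters cytotoxicity at all stays open.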